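Methyl in Place of Chloro: a Step Made Twice

A few compounds are considered here, and "the series" means these few. Any claim that something is new, unique, unknown or untested is made for them only; others in the source may bear on it.

Compound 1, `Clc1cncc(OC[C@@H]2CCN2)c1`, gives 0.042 nM in an assay on brain for binding affinity to Neuronal acetylcholine receptor; alpha4/beta2 (Rattus norvegicus), read by radioligand binding; on this read-out higher numbers stand for weaker inhibition and lower numbers for stronger inhibition.
Compound 2, `Cc1cncc(OC[C@@H]2CCN2)c1`, gives 0.047 nM in this assay.
Compound 3, `Clc1ncccc1OC[C@@H]1CCN1`, gives 2.3 nM in this assay.

Compounds 1 and 3 are built from the same atoms joined differently; the difference between the two cores is not broken down here. Compound 3 stands furthest from compound 1 in this assay. The change from compound 1 to compound 2, (methyl in place of chloro on an aromatic carbon), gave a 1.1-fold higher number from compound 1 to compound 2 (0.05 log units; within the scatter). Compound 4, `Cc1ncccc1OC[C@@H]1CCN1`, is not yet measured; it arises from compound 3 by methyl in place of chloro on an aromatic carbon, the same kind of change, but at a carbon next to the ring nitrogen and ortho to the group of 6 heavy atoms rather than two atoms from the nitrogen and meta to it. Because a 1.1-fold higher number from compound 1 to compound 2 (0.05 log units; within the scatter) stayed within the scatter, a similarly small step, a 1.2-fold lower number from compound 3 to compound 4 (0.06 log units; within the scatter), is expected for compound 4. Compound 4 is estimated at 2 nM in this assay, between 0.7 nM and 6 nM.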

Compound 4, inhibition constant: 1.36 nM
Compound 4: middle estimate off by 1.5-fold (0.17 log units), on the high side; the range from low to high includes it.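

The swap of chloro for methyl on an aromatic carbon gave a 1.7-fold lower number from compound 3 to compound 4 (0.23 log units; within the scatter) in this assay, so on this second core, too, it did not move the number beyond the usual scatter. Set beside the earlier step, the change behaved alike on the two cores, even though it sits at a different place on each: the same change on two cores in this assay, a 1.1-fold higher number (0.05 log units; within the scatter) from compound 1 to compound 2 and a 1.7-fold lower number (0.23 log units; within the scatter) from compound 3 to compound 4, 1.9-fold (0.28 log units) apart, within the scatter of two such steps

This shows that the small effect of the swap carried over between these two cores, but two pairs make no general rule, and they do not show that it would hold on any other core or explain why the two groups read alike. The compounds shown leave open whether a larger or different group at these carbons, such as an amine or a longer chain, would also leave the number unchanged. They also leave open whether the swap would stay this small in a different kind of assay.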